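The compounds below may be only part of what the source reports. "The series", "measured", "known", "first", "only" and "open" are said of these compounds alone.

Three compounds have been measured in an assay on cells for inhibition of matrix metalloproteinase-9 (Homo sapiens), read by fluorescence, with stated times of 15 min and 4 h; on this read-out higher numbers stand for weaker inhibition and lower numbers for stronger inhibition:

compound 1, `O=C(CCc1ccccc1)Nc1cccc(-c2nc3ccccc3[nH]2)c1`, 68000 nM
compound 2, `Cc1cccc2nc(-c3cccc(NC(=O)CCc4ccccc4)c3)[nH]c12`, 60000 nM
compound 3, `Cc1ccc2nc(-c3ccc([N+](=O)[O-])cc3)[nH]c2c1`, 22000 nM

Compound 3 gives the lowest of the three numbers, and the gaps to compound 2 and to compound 1 are both beyond the usual scatter. How the core of compound 3 differs from the core of compound 2 is not broken down here; the two simply differ in more than one place.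

Between compound 2 and compound 1 the change is hydrogen in place of methyl on an aromatic carbon, and the step it made was a 1.1-fold higher number from compound 2 to compound 1 (0.05 log units; within the scatter), a difference that lies within the scatter.

Compound 4, `O=[N+]([O-])c1ccc(-c2nc3ccccc3[nH]2)cc1`, has not yet been measured in this assay. It differs from compound 3 by hydrogen in place of methyl on an aromatic carbon. This is the same kind of change as that from compound 2 to compound 1, but not the same: in compound 2 the methyl that leaves sits ortho to a fused ring and meta to a fused ring, whereas in compound 3 it sits meta to a fused ring and para to a fused ring.

The step that the estimate means, a 1.1-fold higher number from compound 3 to compound 4 (0.04 log units; within the scatter), is expected to be small, and that expectation rests on a 1.1-fold higher number from compound 2 to compound 1 (0.05 log units; within the scatter), where the same kind of change moved the number only within the scatter. Compound 4 is therefore expected to give about 24000 nM in this assay, most likely between 10000 nM and 60000 nM.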

Compound 4, half-maximal inhibitory concentration: 56500 nM
Compound 4: the middle estimate sits 2.4-fold (0.37 log units) below what was measured, and the stated range covers the measured number.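

Hydrogen in place of methyl on an aromatic carbon gave a 2.6-fold higher number from compound 3 to compound 4 (0.41 log units; beyond the scatter) in this assay, so on this core the change moved the number by a modest step. Set beside the earlier step, the gap between the two lies within what two such steps can scatter, and the two cores cannot be told apart on this change: the same change on two cores in this assay, a 1.1-fold higher number (0.05 log units; within the scatter) from compound 2 to compound 1 and a 2.6-fold higher number (0.41 log units; beyond the scatter) from compound 3 to compound 4, 2.3-fold (0.36 log units) apart, within the scatter of two such steps. Among these compounds, this gives no firm sign that the change behaves differently from one core to the other, but with only two steps, on cores that differ in more than one place and with the methyl in a different place on each, it does not show that the change carries over unaltered, and it says nothing about what sets the size of either step.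

The compounds shown leave open whether a group other than methyl at the same place, such as a methoxy group, an amine or a longer chain, would move the number further than hydrogen does. They also leave open whether the step from methyl to hydrogen would hold if the nitro group of compound 3 and compound 4 gave way to a carboxylic acid or an amine.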